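From Phenethyl to a Diallylamino Chain on the Amide

The compounds below may be only part of what the source reports. "The series", "measured", "known", "first", "only" and "open" are said of these compounds alone.

Of the compounds shown here, two sharing one core have been measured in a functional assay on PC-3 cells (Homo sapiens) for cytotoxicity, read by MTT assay, with a stated time of 48 h; on this read-out higher numbers stand for weaker inhibition and lower numbers for stronger inhibition. Compound 1 `CC1=NN(C(=O)c2ccc(C)cc2)C(c2cc(Br)ccc2O)C1` gives 41200 nM, and compound 2 `CC1=NN(C(=O)CCc2ccccc2)C(c2cc(Br)ccc2O)C1` gives 16300 nM. Among the measured compounds shown here, the step of a 2.5-fold lower number from compound 1 to compound 2 (0.40 log units; beyond the scatter) is the only comparison so far. For the measured compounds named here, on these two numbers compound 2 stands lowest, with compound 1 as its sole neighbour.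

Compound 3 `C=CCN(CC=C)CC(=O)N1N=C(C)CC1c1cc(Br)ccc1O` has not yet been measured. It differs from compound 2 by diallylamino in place of benzyl on a saturated chain carbon bound to a carbonyl carbon, so the six-membered aromatic ring of carbon only is gone from the chain and a nitrogen with two allyl groups takes its place. Going by the values given here, no measured step bears directly on this change: the step from compound 1 to compound 2 exchanged an aryl group on the carbonyl carbon for a phenethyl chain, whereas here the aromatic ring of that chain itself is removed. Among the compounds with values here, with no comparable step in hand, the expectation for compound 3 can only be loose; compound 3 is estimated to give 20000 nM, within 6000 nM to 60000 nM. This would be an expected step of a 1.2-fold higher number from compound 2 to compound 3 (0.09 log units; within the scatter), which is not anticipated to go clearly beyond the scatter in either direction.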

Compound 3, half-maximal inhibitory concentration: 3090 nM
Compound 3: middle estimate off by 6.5-fold (0.81 log units), on the high side; the measured number lies below the stated range.
By their numbers in this assay, from the lowest: compound 3; then compound 2; then compound 1.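

At this position, on a saturated chain carbon bound to a carbonyl carbon, the six-membered aromatic ring of the phenethyl chain proves dispensable in this assay: exchanging benzyl for diallylamino gives a 5.3-fold lower number from compound 2 to compound 3 (0.72 log units; beyond the scatter), the first sign that a ring-free group carrying a nitrogen can take this place without loss. Measured against the aryl amide, the change of 4-methylphenyl on a carbonyl carbon for (diallylamino)methyl gives a 13-fold lower number from compound 1 to compound 3 (1.12 log units; beyond the scatter), a step clearly larger than the one earlier seen with phenethyl, so that compound 3 now stands lowest of the three, beyond the scatter from both others. Nothing available on the compounds explains this gain, and the numbers alone record only its size.

The change removes the aromatic ring and brings in a nitrogen and two double bonds all at once, and these compounds do not separate those parts; a dipropylamino or piperidine group in the same place would help to do so. Going by these compounds, whether the gain would hold on a longer chain between the carbonyl and the nitrogen also remains open.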